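Swapping a straight chain for a ring on the sulfur

The source may hold more compounds than are shown below. What is called first, only, known or untested is meant among the compounds shown, and "the series" means these compounds.

Three amides sharing one core have been measured in an assay on cells for antagonist activity at transient receptor potential cation channel subfamily V member 1 (Homo sapiens), read by FLIPR and calcium flux, with a stated time of 6 min; a lower number here means a stronger inhibitor, a higher number a weaker inhibitor. Compound 1 `CCCCN(C)c1nc(C(C)(C)C)ccc1CNC(=O)C(C)c1ccc(NS(C)(=O)=O)c(F)c1` gives 1.2 nM. Compound 2 `CC(C(=O)NCc1ccc(C(C)(C)C)nc1OCc1ccccc1)c1ccc(NS(C)(=O)=O)c(F)c1` gives 4.4 nM. Compound 3 `CCCCCSc1nc(C(C)(C)C)ccc1CNC(=O)C(C)c1ccc(NS(C)(=O)=O)c(F)c1` gives 3.1 nM. The steps show a 3.7-fold higher number from compound 1 to compound 2 (0.56 log units; beyond the scatter) and a 2.6-fold higher number from compound 1 to compound 3 (0.41 log units; beyond the scatter), so compound 3 sits above compound 1 on the numbers, while the pair of compound 2 and compound 3 differ only by a 1.4-fold lower number from compound 2 to compound 3 (0.15 log units; within the scatter), which cannot be told apart from repeat measurement.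

Compound 4 `CC(C(=O)NCc1ccc(C(C)(C)C)nc1SC1CCCC1)c1ccc(NS(C)(=O)=O)c(F)c1` is not yet measured. It differs from compound 3 by cyclopentyl in place of pentyl on a sulfur. Going by the values given here, none of the measured steps changes the shape of a chain while keeping its size: the steps from compound 1 replace the whole group on the aromatic carbon, and the step from compound 2 to compound 3 does the same. Among the compounds with values here, no measured step therefore bears directly on this change, and there is no ground to expect a shift beyond the scatter in this assay in either direction.

For compound 4 the expected outcome is close to that of compound 3, with an estimated step of a 1.1-fold higher number from compound 3 to compound 4 (0.05 log units; within the scatter). Compound 4 is thus estimated at 3.5 nM, within a range from 1.4 nM to 9 nM.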

Compound 4, inhibition constant: 2.5 nM
Compound 4: the middle estimate sits 1.4-fold (0.15 log units) above what was measured, within the range that was stated.
By their numbers in this assay, from the lowest: compound 1; then compounds 4, 3 and 2 (each within the scatter of the next).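

Closing the pentyl chain into a cyclopentyl ring on the sulfur gives a 1.2-fold lower number from compound 3 to compound 4 (0.09 log units; within the scatter) in this assay, so at this position a straight chain and a ring with the same heavy-atom count cannot be told apart, and the measured values leave room for either shape. Putting cyclopentylsulfanyl in place of benzyloxy on the aromatic carbon gives a 1.8-fold lower number from compound 2 to compound 4 (0.25 log units; within the scatter) and likewise separates nothing, while putting it in place of butyl(methyl)amino gives a 2.1-fold higher number from compound 1 to compound 4 (0.32 log units; beyond the scatter), so compound 1 remains the strongest inhibitor of the four, since its steps to compound 2, compound 3 and compound 4 all lie beyond the scatter. No measurement shown offers a reason for either the match between chain and ring or the separate standing of compound 1.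

The compounds shown leave open whether the same freedom holds for other rings on the sulfur, such as cyclopropyl or cyclohexyl, or for a much shorter chain such as methyl. They also leave open whether a cyclopentyl ring would match a butyl chain when attached through the nitrogen of an amine, as in cyclopentyl(methyl)amino, the kind of linking atom found in compound 1.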